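A few compounds are considered here, and "the series" means these few. Any claim that something is new, unique, unknown or untested is made for them only; others in the source may bear on it.

Measured compounds:
- compound 1 `CCC(=O)Nc1cccc(S(=O)(=O)Oc2ccccc2C(C)C)c1`: 25000 nM
- compound 2 `CCCC(=O)Nc1cccc(S(=O)(=O)Oc2ccccc2C(C)C)c1`: 20000 nM
- compound 3 `CCCCCC(=O)Nc1cccc(S(=O)(=O)Oc2ccccc2C(C)C)c1`: 11000 nM

All three share one core and differ only in the chain on the carbonyl carbon of the amide. In a functional assay on M21 cells (Homo sapiens) for antiproliferative activity, read by sulforhodamine B assay, with a stated time of 48 h (on this read-out higher numbers stand for weaker inhibition and lower numbers for stronger inhibition), compound 3 gives the lowest number of the three, but only the gap to compound 1 is beyond the scatter: the step of a 2.3-fold lower number from compound 1 to compound 3 (0.36 log units; beyond the scatter) is modest, while a 1.3-fold lower number from compound 1 to compound 2 (0.10 log units; within the scatter) and a 1.8-fold lower number from compound 2 to compound 3 (0.26 log units; within the scatter) each stay within the scatter. Lengthening the chain thus trends toward lower numbers, yet the trend is shallow and rests on three points.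

Compound 4 `CC(C)C(=O)Nc1cccc(S(=O)(=O)Oc2ccccc2C(C)C)c1` is the next point: isopropyl in place of pentyl on a carbonyl carbon. Going by the values given here, three carbons enter where five leave, so the change reverses the direction of the steps that lowered the number from compound 1 to compound 3, and the branched group is new to the series, with no measured step to anchor it. Among the compounds with values here, the steps that bear on it, a 2.3-fold lower number from compound 1 to compound 3 (0.36 log units; beyond the scatter) and a 1.8-fold lower number from compound 2 to compound 3 (0.26 log units; within the scatter), suggest that taking carbons away from this chain should move the number up by a similar small margin, likely near the edge of the scatter rather than clearly beyond it.

The expected step is therefore a 1.8-fold higher number from compound 3 to compound 4 (0.26 log units; within the scatter), upward. For compound 4 the estimate in this assay is 20000 nM, with a range from 10000 nM to 40000 nM.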

Compound 4, half-maximal inhibitory concentration: 17000 nM
The estimate for compound 4 lay 1.2-fold (0.07 log units) above the measured number; the measured number falls inside the stated range.
By their numbers in this assay, from the lowest: compounds 3, 4, 2 and 1 (each within the scatter of the next, the first and the last beyond it).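

In this assay, going by these compounds alone, isopropyl is the first branched group on this carbonyl carbon, and compound 4 cannot be separated from any of the straight-chain amides: a 1.5-fold higher number from compound 3 to compound 4 (0.19 log units; within the scatter), a 1.2-fold lower number from compound 2 to compound 4 (0.07 log units; within the scatter) and a 1.5-fold lower number from compound 1 to compound 4 (0.17 log units; within the scatter). Branching at this place therefore brings no step beyond the scatter, and the only such step among the four compounds remains a 2.3-fold lower number from compound 1 to compound 3 (0.36 log units; beyond the scatter), so the shallow trend with chain length gains no firmer support from compound 4, whose isopropyl group lies outside a straight-chain series. No measurement at hand accounts for how little the number changes with this swap.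

Open, going by these compounds, is whether a chain longer than pentyl, a tert-butyl group or a cyclohexyl ring on this carbonyl carbon would give a step clearly beyond the scatter, and so show if branching and chain length have separate effects here. Also open, on these data alone, is whether an amine or a carboxylic acid at the end of the chain would move the number in this assay at all.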